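The source may report more compounds than this note shows. Statements on the series, on what has been measured and on what is new or still open speak of the compounds shown alone.

Measured in an ADME assay on L929 cells (Mus musculus) for cytotoxicity, with a stated time of 72 h; on this read-out lower numbers stand for stronger inhibition and higher numbers for weaker inhibition:
- Compound 1 `CCOC(=O)COc1ccc2c(c1)B(O)OC2`: > 10 ug/mL
- Compound 2 `COC(=O)COc1ccc2c(c1)B(O)OC2`: > 10 ug/mL

In this assay compound 2 gives > 10 ug/mL, which is a limit of the assay and not a number. Compound 1 also gives only a limit, so what the pair shares is the limit of > 10 ug/mL in this assay, at which 2 of the 2 values shown sit.

Compound 3 `CC(C)(C)OC(=O)COc1ccc2c(c1)B(O)OC2` keeps the shared core and has tert-butyl in place of methyl on an oxygen next to a carbonyl group. Going by the values given here, the only measured step that bears on this change is a step that the two limits leave unreadable from compound 1 to compound 2. It also alters the chain end of the molecule, but no size or direction can be read from it, so it gives nothing to carry over to compound 3. The most likely outcome is therefore another limit rather than a clear change in either direction. The expected size is a step that the limit leaves unreadable from compound 2 to compound 3, and this estimate favours no direction. Compound 3 is estimated at 15 ug/mL, with an expected range from 8 ug/mL to 40 ug/mL.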

Compound 3, half-maximal inhibitory concentration: > 10 ug/mL
Compound 3 ended at the assay's limit (the forecaster's own chance of this, stated with the estimate: 80%); the middle value lies beyond the limit too.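

No step can be read among compound 1, compound 2 and compound 3, since each gives only a limit of the assay and not a number: the limit of > 10 ug/mL in this assay, at which 3 of the 3 values shown sit. Going by these compounds, whether tert-butyl in place of methyl changes the result in this assay at all stays open, and so does the actual value of each of the three compounds.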